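A few compounds are considered here, and "the series" means these few. Any claim that something is new, unique, unknown or untested is made for them only; others in the source may bear on it.

Compound 3 `O=C(Nc1cc(-c2ccccc2)nn1-c1ccccc1Br)c1ccc([N+](=O)[O-])cc1` gives 120 nM in an assay on HEK293 cells for displacement of a labelled ligand from metabotropic glutamate receptor 5 (Rattus norvegicus) (on this read-out lower numbers stand for stronger inhibition and higher numbers for weaker inhibition), the lowest of the three numbers measured. Compound 1 `O=C(Nc1cc(-c2ccccc2)nn1-c1ccccc1)c1cccc([N+](=O)[O-])c1` gives 2220 nM and compound 2 `O=C(Nc1cc(-c2ccccc2)nn1-c1ccccc1Br)c1ccccc1` gives 2600 nM, and these two values lie within the scatter of each other. Compound 4 `O=C(Nc1cc(-c2ccccc2)nn1-c1ccccc1Br)c1cccc([N+](=O)[O-])c1` differs from compound 3 by 3-nitrophenyl in place of 4-nitrophenyl on a carbonyl carbon. For the measured compounds named here, the only single-change step bearing on this is a 22-fold lower number from compound 2 to compound 3 (1.34 log units; beyond the scatter), which shows what the 4-nitrophenyl brings. Compound 1 carries the 3-nitrophenyl yet sits no lower than compound 2, so the same gain is not assured for compound 4. A step of a 6.7-fold higher number from compound 3 to compound 4 (0.82 log units; beyond the scatter) is therefore expected, a weaker number, though not back to the level of compound 2. For compound 4 the estimate is 800 nM, within 200 nM to 3000 nM.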

Compound 4, inhibition constant: 230 nM
Compound 4: the middle estimate sits 3.5-fold (0.54 log units) above what was measured; the measured number falls inside the stated range.
By their numbers in this assay, from the lowest: compounds 3 and 4 (each within the scatter of the next); then compounds 1 and 2 (each within the scatter of the next).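

In this assay, 3-nitrophenyl in place of 4-nitrophenyl on the carbonyl carbon gives a 1.9-fold higher number from compound 3 to compound 4 (0.28 log units; within the scatter), so these two groups cannot be told apart here. The gain from adding a nitro is therefore not confined to 4-nitrophenyl, as an 11-fold lower number from compound 2 to compound 4 (1.05 log units; beyond the scatter) shows. Compound 1 had left this hidden, and the bromo proves to count alongside 3-nitrophenyl, with a 9.7-fold lower number from compound 1 to compound 4 (0.98 log units; beyond the scatter).

Nothing measured here explains why these steps arise. Going by these compounds, whether an amine or a carboxylic acid could stand in place of the nitro remains open.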